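The source may hold more compounds than are shown below. What is called first, only, known or untested is meant among the compounds shown, and "the series" means these compounds.

Measured compounds:
Compound 1, `COc1cc(Cc2nc3c(N)nc(F)nc3n2CCOC(C)C)cc(OC)c1OC`: 15800 nM
Compound 2, `COc1cc(Cc2nc3c(N)ncnc3n2CCOC(C)C)cc(OC)c1OC`: 38900 nM
Compound 3, `CCCCn1c(Cc2cc(OC)c(OC)c(OC)c2Br)nc2c(N)ncnc21`: 25100 nM

These three compounds were tested in a functional assay on MCF7 cells (Homo sapiens) for antiproliferative activity; a lower number here means a stronger inhibitor, a higher number a weaker inhibitor. Compound 2 gives the highest number of the three: compound 3 is within the scatter of it, while compound 1 differs by a step beyond the scatter, a 2.5-fold higher number from compound 1 to compound 2 (0.39 log units; beyond the scatter), a change of hydrogen in place of fluoro on an aromatic carbon.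

Compound 4, `C/C=C/Cn1c(Cc2cc(OC)c(OC)c(OC)c2)nc2c(N)ncnc21`, has not yet been measured. It differs from compound 2 in this way: prop-1-en-1-yl in place of isopropoxymethyl on a saturated chain carbon bound to an aromatic nitrogen. Within the data shown here, no measured pair shows this change, so no step bears on it directly. Compound 3 carries a different chain on the same aromatic nitrogen together with a bromo group, and its value sits within the scatter of compound 2, which hints that changes of this chain may matter little here, though compound 3 is not a clean comparison. The expectation is therefore a step of a 1.3-fold lower number from compound 2 to compound 4 (0.11 log units; within the scatter), not beyond the scatter. Compound 4 is estimated at 30000 nM, with a range from 10000 nM to 100000 nM.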

Compound 4, half-maximal inhibitory concentration: 51300 nM
Compound 4: middle estimate off by 1.7-fold (0.23 log units), on the low side; the range from low to high includes it.
By their numbers in this assay, from the lowest: compounds 1, 3, 2 and 4 (each within the scatter of the next, the first and the last beyond it).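

Among these compounds, this is the first comparison in which only the chain on the aromatic nitrogen differs. In this assay, but-2-en-1-yl in place of 2-isopropoxyethyl gives a difference within the scatter (a 1.3-fold higher number from compound 2 to compound 4 (0.12 log units; within the scatter)). So, in this pair, losing the oxygen and the hydrogen-bond acceptor it is counted as, and going from 5 heavy atoms to 3 in the changing group, produces no change that can be read, and no measurement here offers an explanation for this.

The compounds shown leave open whether a chain ending in an amine or a carboxylic acid, or a longer alkyl chain, would move the number beyond the scatter. They also leave open whether fluoro in place of hydrogen on the aromatic carbon would give a similar step with but-2-en-1-yl on the nitrogen.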